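From 3-methoxyphenyl to 4-methoxyphenyl at the limit

A few compounds are considered here, and "the series" means these few. Any claim that something is new, unique, unknown or untested is made for them only; others in the source may bear on it.

In an ADME assay on MDBK cells (Bos taurus) for cytotoxicity (on this read-out lower numbers stand for higher toxicity in this test and higher numbers for lower toxicity in this test), compound 3 (`COc1cccc(Cn2ccc3nc(-c4ccccc4)nc-3c2)c1`) gives > 100000 nM, which is a limit and not a number. Compound 1 (`c1ccc(Cn2ccc3nc(-c4ccccc4)nc-3c2)cc1`) gives > 100000 nM, also a limit. Compound 2 (`Cc1ccc(Cn2ccc3nc(-c4ccccc4)nc-3c2)cc1`) gives > 100000 nM, again a limit. Compound 4 (`COc1ccc(Cn2ccc3nc(-c4ccccc4)nc-3c2)cc1`) has 4-methoxyphenyl in place of 3-methoxyphenyl on a saturated chain carbon bound to an aromatic nitrogen. The measured steps that bear on this change are a step that the two limits leave unreadable from compound 1 to compound 3 and a step that the two limits leave unreadable from compound 2 to compound 3, and neither has a measurable size. Within the data shown here, the only evidence is the limit of > 100000 nM in this assay, at which 3 of the 3 values shown sit. On that basis, the expected step is a number no higher from compound 3 to compound 4 (the limit leaves the size open), with no direction and nothing beyond the scatter. For compound 4 the estimated value is 100000 nM, with an expected range from 40000 nM to 200000 nM.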

Compound 4, half-maximal cytotoxic concentration: > 100000 nM
Compound 4 was reported as a limit; the forecaster's own chance of this, stated with the estimate: 85%; the middle value sits exactly at the limit.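

In this assay, among these compounds, compound 4 is reported only as a limit, like compound 1, compound 2 and compound 3, and no step among them can be read. The compounds shown leave open how far these four differ in this read-out, if they differ at all: the limit of > 100000 nM in this assay, at which 4 of the 4 values shown sit.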